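This account rests on a few compounds, and the source may have more. Where it says the series, first, only, none or still open, it means among the compounds named here.

Compound 1 `O=C(/C=C\Nc1ccc2cc[nH]c2c1)c1nc(-c2ccc(C(F)(F)F)cc2)n2ccccc12`: > 30000 nM
Compound 2 `O=C(/C=C\Nc1cnc2ccccc2c1)c1nc(-c2ccccc2)n2ccccc12`: 19700 nM
Compound 3 `Cc1cc2cc(N/C=C\C(=O)c3nc(-c4ccc(F)cc4)n4ccccc34)ccc2[nH]1`: > 30000 nM

In a functional assay on BT-474 cells (Homo sapiens) for cytotoxicity, read by MTT assay, with a stated time of 48 h (a lower number here means a stronger inhibitor, a higher number a weaker inhibitor), compound 1 gives > 30000 nM, which is a limit of the assay rather than a number. Compound 1 thus stands at the limit of > 30000 nM in this assay, at which 2 of the 3 values shown sit. Compound 3 also gives only a limit, > 30000 nM. Compound 2 gives a number, 19700 nM, which is weak. Among the measured compounds shown here, no single-change step between measured compounds is available, so no measured step size can guide the next one. Compound 4 `COc1ccc(N/C=C\C(=O)c2nc(-c3ccc(C(F)(F)F)cc3)n3ccccc23)cc1` differs from compound 1 by 4-methoxyphenyl in place of 1H-indol-6-yl on an amine nitrogen. Since compound 1 sits at a limit, the expected step is a number no higher from compound 1 to compound 4 (the limit leaves the size open), nothing beyond the usual scatter. Compound 4 is expected to give about 30000 nM, with a plausible range from 8000 nM to 100000 nM, and it may well again return only a limit.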

Compound 4, half-maximal inhibitory concentration: > 30000 nM
Compound 4: only a limit was reported (the forecaster's own chance of this, stated with the estimate: 55%); the middle value sits exactly at the limit.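

Compound 1 and compound 4 each return only a limit of the assay, not a number, so no step can be read between them. The compounds shown leave open whether 4-methoxyphenyl in place of 1H-indol-6-yl changes potency at all.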